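This account rests on a few compounds, and the source may have more. Where it says the series, first, only, none or still open, it means among the compounds named here.

Compound 1 `CC(C)c1ccccc1NC(=O)NCC1(c2ccccc2)CCCCC1` gives 390 nM in an assay on microsomes from intestine for inhibition of acyl-CoA:cholesterol acyltransferase (Oryctolagus cuniculus); on this read-out lower numbers stand for stronger inhibition and higher numbers for weaker inhibition. Compound 2 `COc1cccc(NC(=O)NCC2(c3ccccc3)CCCCC2)c1` gives 2500 nM in this assay, the highest of the two numbers shown; compound 1 sits at a lower number by a gap beyond the usual scatter. Compound 3 `O=C(NCC1(c2ccccc2)CCCCC1)Nc1ccc(Cl)cc1` differs from compound 2 by 4-chlorophenyl in place of 3-methoxyphenyl on an amide-type nitrogen. Within the data shown here, no measured pair shows this exchange, so the direction is uncertain; a modest move toward a lower number is expected, possibly not beyond the scatter. The expected step from compound 2 to compound 3 is a 1.7-fold lower number from compound 2 to compound 3 (0.22 log units; within the scatter). Compound 3 is expected to give about 1500 nM in this assay, with a range from 400 nM to 6000 nM.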

Compound 3, half-maximal inhibitory concentration: 2200 nM
The estimate for compound 3 lay 1.5-fold (0.17 log units) below the measured number; the range from low to high includes it.
By their numbers in this assay, from the lowest: compound 1; then compounds 3 and 2 (each within the scatter of the next).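

In this assay, putting 4-chlorophenyl in place of 3-methoxyphenyl on an amide-type nitrogen gives a 1.1-fold lower number from compound 2 to compound 3 (0.06 log units; within the scatter), so this exchange leaves the number within the scatter. The leaving group carries a hydrogen-bond acceptor and the entering group carries none, yet compound 2 and compound 3 read alike here. No measurement bears on why this is so.

As far as these compounds go, whether an aminophenyl or a carboxyphenyl group in the same place would shift the number stays open. So does what separates compound 1 from the other two.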